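Cyclobutylmethyl for cyclopropyl on the amide nitrogen

The source may report more compounds than this note shows. Statements on the series, on what has been measured and on what is new or still open speak of the compounds shown alone.

Compound 1, `CCN(Cc1ccccc1)C(=O)C1CCN(S(=O)(=O)c2ccc(OC)cc2)CC1`: 84% in a functional assay on CHO cells for positive allosteric modulation of muscarinic acetylcholine receptor M5 (Homo sapiens), read by calcium flux; on this read-out higher numbers stand for larger maximal responses and lower numbers for smaller maximal responses
Compound 2, `CCN(C(=O)C1CCN(S(=O)(=O)c2ccc(OC)cc2)CC1)[C@@H](C)c1ccccc1`: "not determined" (no result reported) in this assay
Compound 3, `O=C(C1CCN(S(=O)(=O)c2ccc3[nH]ncc3c2)CC1)N(Cc1ccccc1C(F)(F)F)C1CC1`: "not determined" (no result reported) in this assay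

Compound 3 stands without a number in this assay; the only measured point in the series is compound 1, and compound 2 likewise has no result. Compound 4, `O=C(C1CCN(S(=O)(=O)c2ccc3[nH]ncc3c2)CC1)N(Cc1ccccc1C(F)(F)F)CC1CCC1`, differs from compound 3 as follows: cyclobutylmethyl in place of cyclopropyl on an amide-type nitrogen. Among the measured compounds shown here, no measured step between compounds exists, so the size of the effect of this change in this assay cannot be read from the data; a shift within the scatter, in either direction, is the plain expectation. Compound 4 is estimated at 75% in this assay, with a range of 40% to 110%, leaning on compound 1 at 84%.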

Compound 4, largest response reached (reported as percent of maximum), in percent of the reference or control that the assay uses: 103%
Beside the measured number, compound 4's estimate is 28 percentage points below it; the measured number falls inside the stated range.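

Among the compounds shown here, no step from compound 3 to compound 4 can be read in this assay, as compound 3 has no single number there. As far as these compounds go, what cyclobutylmethyl in place of cyclopropyl does to the maximal response stays open. No supporting data bear on this result.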